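Difluorophenyl in place of trifluoromethylphenyl on the carbonyl

This account rests on a few compounds, and the source may have more. Where it says the series, first, only, none or still open, it means among the compounds named here.

Compound 1 `CN(C(=O)NC(=O)c1cccc(C(F)(F)F)c1)c1nc(C(F)(F)F)c(C(=O)N/N=C/c2cccc(C(F)(F)F)c2)s1` is the starting point. Among the measured compounds shown here, in a functional assay on HeLa cells (Homo sapiens) for inhibition, read by MTT assay, with a stated time of 72 h (a lower number here means a stronger inhibitor, a higher number a weaker inhibitor), compound 1 gives 4.81 ug/mL, one of only two numbers recorded here, and its one near relative, compound 2 `CN(C(=O)NC(=O)c1cccc(C(F)(F)F)c1)c1nc(C(F)(F)F)c(C(=O)N/N=C/c2ccccc2C(F)(F)F)s1`, gives 7.37 ug/mL. For the measured compounds named here, the single measured step, a 1.5-fold higher number from compound 1 to compound 2 (0.19 log units; within the scatter), describes 2-(trifluoromethyl)phenyl in place of 3-(trifluoromethyl)phenyl on a carbon with a double bond to nitrogen. Compound 3 `CNc1nc(C)c(C(=O)N/N=C/c2ccccc2C(F)(F)F)s1` gives > 100 ug/mL, which is a limit of the assay rather than a number (the limit of > 100 ug/mL in this assay, at which 1 of the 3 values shown sits).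

Compound 4 `CN(C(=O)NC(=O)c1c(F)cccc1F)c1nc(C(F)(F)F)c(C(=O)N/N=C/c2cccc(C(F)(F)F)c2)s1` differs from compound 1 in one place: 2,6-difluorophenyl in place of 3-(trifluoromethyl)phenyl on a carbonyl carbon. Going by the values given here, this change is not on the carbon with a double bond to nitrogen where the measured step was made, so no measured step bears on it directly. Among the compounds with values here, the step from compound 1 to compound 2 shows only that one aryl change elsewhere stayed within the scatter, and compound 3 differs from compound 1 in more than one place, so its limit cannot be tied to the carbonyl side. With nothing pointing either way, the expected step is a 1.2-fold higher number from compound 1 to compound 4 (0.10 log units; within the scatter), that is, no change beyond the scatter. Compound 4 is therefore estimated at 6 ug/mL, within a range from 2.5 ug/mL to 15 ug/mL.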

Compound 4, half-maximal inhibitory concentration: 21.6 ug/mL
Compound 4: middle estimate off by 3.6-fold (0.56 log units), on the low side; measured number outside the range, above it.
By their numbers in this assay, from the lowest: compounds 1 and 2 (each within the scatter of the next); then compound 4. At a limit, above all of these: compound 3.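

Replacing 3-(trifluoromethyl)phenyl with 2,6-difluorophenyl on this carbonyl carbon, whose other neighbour is an amide-type nitrogen, produces a real difference in this assay (a 4.5-fold higher number from compound 1 to compound 4 (0.65 log units; beyond the scatter)), so the aryl group at this position affects the reading, though the step is modest. Among the compounds shown here, the earlier step at the other aryl position (a 1.5-fold higher number from compound 1 to compound 2 (0.19 log units; within the scatter)) gave no such signal, which makes this the first change in a single place to show a difference larger than the usual variation between repeat measurements. Because this swap alters both the kind of fluorinated substituent and where it stands on the ring, a single step cannot show which of the two matters.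

As far as these compounds go, it remains open how this carbonyl position would respond to other groups, such as a methoxy group, an amine or a carboxylic acid on the aryl ring, or to a 2-(trifluoromethyl)phenyl or a single fluorine there. No measurement given here offers a cause for the step.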